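The compounds below may be only part of what the source reports. "The series", "measured", "known", "first", "only" and "open" are said of these compounds alone.

In a functional assay on Ehrlich cells (Homo sapiens) for cytotoxicity, read by MTT assay, with a stated time of 48 h (on this read-out higher numbers stand for weaker inhibition and lower numbers for stronger inhibition), compound 2 `Cc1ccc(C(C2c3onc(C)c3N=C(c3ccccc3)CC2c2ccccc2)C2c3onc(C)c3N=C(c3ccccc3)CC2c2ccccc2)cc1` gives 48.2 ug/mL. Compound 1 `Cc1noc2c1N=C(c1cccs1)CC(c1ccccc1)C2C(c1ccccc1)C1c2onc(C)c2N=C(c2cccs2)CC1c1ccccc1` gives 26.1 ug/mL in this assay, and the gap between compound 1 and compound 2 lies within the scatter, so the two numbers cannot be told apart. Compound 3 `Cc1noc2c1N=C(c1ccccc1)CC(c1ccccc1)C2C(c1ccc(Cl)cc1)C1c2onc(C)c2N=C(c2ccccc2)CC1c1ccccc1` differs from compound 2 by chloro in place of methyl on an aromatic carbon. Among the measured compounds shown here, no step between measured compounds shows what this change does, so no shift beyond the scatter is expected in this assay. Compound 3 is expected to give about 45 ug/mL in this assay, with a range from 20 ug/mL to 100 ug/mL. The expected step of a 1.1-fold lower number from compound 2 to compound 3 (0.03 log units; within the scatter) is thus estimated to stay within the scatter.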

Compound 3, half-maximal inhibitory concentration: 60.4 ug/mL
Compound 3: middle estimate off by 1.3-fold (0.13 log units), on the low side; measured number inside the range.
By their numbers in this assay, from the lowest: compounds 1, 2 and 3 (each within the scatter of the next, the first and the last beyond it).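

In this assay, among the compounds shown here, the change from 4-methylphenyl to 4-chlorophenyl gives a 1.3-fold higher number from compound 2 to compound 3 (0.10 log units; within the scatter) and is the first direct reading of this place, on a six-membered aromatic ring of carbon only, para to a large group. In this one pair, chloro and methyl at this place cannot be told apart. Nothing at hand offers an explanation for this result.

Going by these compounds, it remains open whether an amine or a carboxylic acid at this place would move the number beyond the scatter. The compounds shown also leave open whether a longer chain there would do so.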